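Swapping Phenyl for 3-Methoxybenzyl: An Expected Agonist Step

The compounds below may be only part of what the source reports. "The series", "measured", "known", "first", "only" and "open" are said of these compounds alone.

Of the compounds shown here, three built on one shared core have been tested in an in vitro functional assay on cells for agonist activity at Bombesin receptor subtype-3 (Homo sapiens), read by luminescence and calcium flux; a higher number here means that more compound is needed for the effect, a lower number that less compound is needed. Compound 1 `O=C(O)c1ccccc1-c1ccc(CCc2ncc(-c3ccccc3)[nH]2)cc1` gives 4950 nM in this assay, the highest of the three numbers. Compound 2 `CC(C)(C)Cc1cnc(CCc2ccc(-c3ccccc3C(=O)O)cc2)[nH]1`, with neopentyl in place of phenyl on an aromatic carbon, gives 106 nM, and compound 3 `N#Cc1cccc(Cc2cnc(CCc3ccc(-c4ccccc4C(=O)O)cc3)[nH]2)c1`, which carries 3-cyanobenzyl in place of phenyl on an aromatic carbon, gives 812 nM. The measured steps are a 47-fold lower number from compound 1 to compound 2 (1.67 log units; beyond the scatter) and a 6.1-fold lower number from compound 1 to compound 3 (0.79 log units; beyond the scatter); between the two replacements there is a 7.7-fold higher number from compound 2 to compound 3 (0.88 log units; beyond the scatter).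

Compound 4 `COc1cccc(Cc2cnc(CCc3ccc(-c4ccccc4C(=O)O)cc3)[nH]2)c1` has not yet been measured in this assay. It differs from compound 1 in a single place: 3-methoxybenzyl in place of phenyl on an aromatic carbon. The step from compound 1 to compound 3 bears most directly on this change because a 6.1-fold lower number from compound 1 to compound 3 (0.79 log units; beyond the scatter) came from a benzyl group carrying one substituent at the same place, while the larger step from compound 1 to compound 2 shows how far a non-aromatic group can go. A modest drop in the number, beyond the scatter, is therefore expected. Compound 4 is estimated to give 500 nM in this assay, with a likely range from 150 nM to 1700 nM. That estimate corresponds to an expected step of a 9.9-fold lower number from compound 1 to compound 4 (1.00 log units; beyond the scatter).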

Compound 4, half-maximal effective concentration: 4120 nM
Compound 4: the middle estimate sits 8.2-fold (0.92 log units) below what was measured, outside the stated range (above it).
By their numbers in this assay, from the lowest: compound 2; then compound 3; then compounds 4 and 1 (each within the scatter of the next).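

In this assay, 3-methoxybenzyl in place of phenyl on an aromatic carbon gives a 1.2-fold lower number from compound 1 to compound 4 (0.08 log units; within the scatter), so at this place on the shared core, a benzyl group carrying one substituent does not by itself bring a drop in the number. What the substituent is matters here: methoxy in place of cyano gives a 5.1-fold higher number from compound 3 to compound 4 (0.71 log units; beyond the scatter), so the step seen with 3-cyanobenzyl does not carry over to 3-methoxybenzyl, and the replacement of tert-butyl by 3-methoxyphenyl on the saturated chain carbon gives a 39-fold higher number from compound 2 to compound 4 (1.59 log units; beyond the scatter), which leaves the aromatic group with methoxy far from the neopentyl result. Nothing available accounts for the different outcomes with cyano and methoxy on this benzyl group.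

The compounds shown leave open where plain benzyl, with no substituent on its ring, would fall relative to 3-cyanobenzyl and 3-methoxybenzyl, and whether 3-aminobenzyl would follow either of them. They also leave open whether a longer alkyl chain in place of neopentyl would keep, lose or extend the large step seen with that group.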